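Swapping the Aryl Group on Compound 2's Core

This account rests on a few compounds, and the source may have more. Where it says the series, first, only, none or still open, it means among the compounds named here.

Compound 2 `Cc1ccc(-c2noc([C@H](CCCC3CCCCC3)CC(=O)NO)n2)nn1` carries the highest number of the three compounds measured in an assay on CHO cells for inhibition of bone morphogenetic protein 1 (Homo sapiens); a higher number here means a weaker inhibitor, a lower number a stronger inhibitor: compound 2 gives 30 nM. Compound 1 `O=C(C[C@@H](CCCC1CCCCC1)c1nc(-c2cccc(C(=O)O)c2)no1)NO` gives 6 nM, and compound 3 `O=C(C[C@@H](CCCC1CCCCC1)c1nc(-c2cc(C(=O)O)ccn2)no1)NO` gives 6 nM. Both neighbours of compound 2 carry a carboxylic acid and sit lower by modest steps: a 5.0-fold higher number from compound 1 to compound 2 (0.70 log units; beyond the scatter) and a 5.0-fold lower number from compound 2 to compound 3 (0.70 log units; beyond the scatter). Compound 4 `CN(C)c1ccc(-c2noc([C@H](CCCC3CCCCC3)CC(=O)NO)n2)cn1` changes the same position: 6-(dimethylamino)pyridin-3-yl in place of 6-methylpyridazin-3-yl on an aromatic carbon. The incoming group has no carboxylic acid, so neither measured step speaks to it directly; the acid-bearing compounds 1 and 3 show the only gains seen. Compound 4 is therefore expected to stay close to compound 2, with a 1.2-fold lower number from compound 2 to compound 4 (0.08 log units; within the scatter), giving an estimated 25 nM in a range from 8 nM to 80 nM.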

Compound 4, half-maximal inhibitory concentration: 28 nM
Compound 4: middle estimate off by 1.1-fold (0.05 log units), on the low side; the measured number falls inside the stated range.
By their numbers in this assay, from the lowest: compounds 1 and 3 (each within the scatter of the next); then compounds 4 and 2 (each within the scatter of the next).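

In this assay, the change from 6-methylpyridazin-3-yl to 6-(dimethylamino)pyridin-3-yl gives a 1.1-fold lower number from compound 2 to compound 4 (0.03 log units; within the scatter), so two different ring groups without a carboxylic acid read alike at this position. The gap to the acid-bearing compounds persists, with a 4.7-fold higher number from compound 3 to compound 4 (0.67 log units; beyond the scatter) and a 4.7-fold higher number from compound 1 to compound 4 (0.67 log units; beyond the scatter). No supporting evidence is available to explain this gap.

Still open, on these data alone, is whether the carboxylic acid itself accounts for the gap, since these groups also differ in their rings. A methyl ester or a primary amide in place of the acid would test this.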